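A few compounds are considered here, and "the series" means these few. Any claim that something is new, unique, unknown or untested is made for them only; others in the source may bear on it.

This account follows one change made to compound 1 (`C(=N/Nc1nc(-c2ccccc2)cs1)\C1CCCCC1`), a hydrazone in which a cyclohexyl group hangs from the shared core. In an ADME assay on Vero cells (Chlorocebus sabaeus) for cytotoxicity, read by MTT assay, with a stated time of 48 h (on this read-out lower numbers stand for stronger inhibition and higher numbers for weaker inhibition), compound 1 gives only a limit of the assay, > 100000 nM, rather than a number. The second measured compound, compound 2 (`COc1ccc(/C=N/Nc2nc(-c3ccc(Cl)cc3)cs2)cc1OC`), carries different substituents on both ends of the same core. In this assay compound 2 likewise gives only a limit, > 100000 nM. The two values therefore tell the same thing: the limit of > 100000 nM in this assay, at which 2 of the 2 values shown sit. Going by the values given here, compound 1 thus stands at the edge of what this assay can report, with no measured step to any neighbour that would show how a small change shifts the read-out.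

The new compound, compound 3 (`COc1ccc(-c2csc(N/N=C/C3CCCCC3)n2)cc1`), differs from compound 1 by methoxy in place of hydrogen on an aromatic carbon. Both measured compounds sit at the limit, so a step beyond the usual scatter in either direction is not expected, and the step from compound 1 to compound 3 is expected to be a step that the limit leaves unreadable from compound 1 to compound 3. For compound 3 in this assay the estimate is 150000 nM, within 50000 nM to 500000 nM, most likely reported again as a limit.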

Compound 3, half-maximal inhibitory concentration: > 100000 nM
Compound 3 gave a limit, no number; the forecaster's own chance of this, stated with the estimate: 85%; the middle value is on the limit's open side.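

In this assay, going by these compounds alone, compound 3 gives > 100000 nM, again a limit and not a number, so no step between compound 1 and compound 3 can be read: the limit of > 100000 nM in this assay, at which 3 of the 3 values shown sit. The compounds shown leave open what concentration, if any, gives half-maximal inhibition in this assay, and whether methoxy in place of hydrogen shifts the read-out at all.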